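Adding a Propyl Group to Compound 1

This account rests on a few compounds, and the source may have more. Where it says the series, first, only, none or still open, it means among the compounds named here.

- compound 1 `CC(=O)OCCC(=O)O[C@H](CC=C(C)C)C1=CC(=O)c2c(O)ccc(O)c2C1=O` gives 17300 nM
- compound 2 `CCC(O)CO[C@H](CC=C(C)C)C1=CC(=O)c2c(O)ccc(O)c2C1=O` gives 28700 nM

In a functional assay on HeLa cells (Homo sapiens) for cytotoxicity, read by MTT assay (a higher number here means a weaker inhibitor, a lower number a stronger inhibitor), compound 1 gives 17300 nM, level with compound 2 once scatter is allowed for: a 1.7-fold higher number from compound 1 to compound 2 (0.22 log units; within the scatter). Compound 3 `CCCC(CC(=O)O[C@H](CC=C(C)C)C1=CC(=O)c2c(O)ccc(O)c2C1=O)OC(C)=O` changes compound 1 in one place, turning 2-acetoxyethyl into 2-acetoxypentyl: propyl in place of hydrogen on a saturated chain carbon bound to an oxygen next to a carbonyl group and a saturated chain carbon. Among the measured compounds shown here, the only measured step, a 1.7-fold higher number from compound 1 to compound 2 (0.22 log units; within the scatter), swaps a different group, so it bears only loosely on this change. For the measured compounds named here, no measured pair tests an added propyl, so no shift beyond the scatter is expected. The expected step is a 1.2-fold lower number from compound 1 to compound 3 (0.06 log units; within the scatter). The estimate for compound 3 is 15000 nM, with an expected range from 6000 nM to 35000 nM.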

Compound 3, half-maximal inhibitory concentration: 51200 nM
Compound 3: the middle estimate sits 3.4-fold (0.53 log units) below what was measured, outside the stated range (above it).
By their numbers in this assay, from the lowest: compounds 1, 2 and 3 (each within the scatter of the next, the first and the last beyond it).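

In this assay the added propyl gives a 3.0-fold higher number from compound 1 to compound 3 (0.47 log units; beyond the scatter) and so, unlike the earlier swap of a different group, moves the number beyond the scatter. This saturated chain carbon bound to an oxygen is therefore not indifferent to what it carries, since a propyl group here costs some inhibition. The data offer no explanation for this loss.
Whether any group at this carbon brings a similar loss stays open, because only propyl is shown. A smaller methyl, a longer chain or an amine there could show whether the loss tracks chain length.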